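The source may hold more compounds than are shown below. What is called first, only, known or untested is meant among the compounds shown, and "the series" means these compounds.

Working notes on the series.

Three compounds carry numbers in a functional assay on the whole organism (strain Sprague-Dawley) for inhibition, with Rattus norvegicus as the target; on this read-out lower numbers stand for an effect already at smaller amounts and higher numbers for an effect only at larger amounts of compound. Compound 1 `CCc1cccc2cc(C(=O)O)cnc12` gives only a limit of the assay, > 50 mg/kg, as recorded in the limit of > 50 mg/kg in this assay, at which 1 of the 3 values shown sits. Compound 2 `c1ccc2ncc(-c3nn[nH]n3)cc2c1` gives 10 mg/kg. Compound 3 `CCc1cccc2c(=O)c(-c3nn[nH]n3)c[nH]c12` gives 0.312 mg/kg, the lowest of the two numbers shown; compound 2 is the nearest, with a number beyond the scatter higher than that of compound 3. Within the data shown here, no step between measured compounds differing in one place is available, so the present step is read from the structures alone.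

Compound 4 `O=c1c(-c2nn[nH]n2)c[nH]c2c(Br)cccc12` has not yet been measured in this assay. It differs from compound 3 as follows: bromo in place of ethyl on an aromatic carbon. The bromo group enters at the same aromatic carbon that the ethyl group leaves.

The step from compound 3 to compound 4 is expected to be small, with no clear direction beyond the scatter, as a change of a 1.6-fold higher number from compound 3 to compound 4 (0.20 log units; within the scatter). For compound 4 the expected value in this assay is 0.5 mg/kg, with a range from 0.15 mg/kg to 1.6 mg/kg.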

Compound 4, minimum effective dose: > 5 mg/kg
Compound 4: no number, only a limit; the forecaster's own chance of this, stated with the estimate: 5%; middle value at least 10-fold (1.00 log units) away from the limit.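

At this aromatic carbon, ortho to a fused ring, bromo and ethyl are not interchangeable: in this assay the record gives an at least 16-fold higher number from compound 3 to compound 4 (1.20 log units; beyond the scatter). Among these compounds, this is the first step that differs in one place, and it shows that the value of the shared core depends strongly on the group at this carbon, beyond the scatter. The reading for compound 4 is a limit, not a number: the limit of > 5 mg/kg in this assay, at which 1 of the 4 values shown sits.

The compounds shown give no cause for the step, and they leave open whether it reflects the loss of ethyl or the arrival of bromo. Chloro, methoxy or a longer chain such as propyl on the same aromatic carbon would help to separate these two readings.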